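The compounds below may be only part of what the source reports. "The series", "measured", "known", "first", "only" and "open" are said of these compounds alone.

- Compound 1 `Cn1cc(-c2ccccc2F)c2cc(C(=O)NCc3ccc(C(=O)Nc4ccccc4N)cc3)[nH]c2c1=O`: 230 nM
- Compound 2 `Cn1cc(-c2cccc(F)c2)c2cc(C(=O)NCc3ccc(C(=O)Nc4ccccc4N)cc3)[nH]c2c1=O`: 210 nM

Among the compounds with values here, in a functional assay on MV4-11 cells (Homo sapiens) for antiproliferative activity, read by CCK-8 assay, with a stated time of 72 h (on this read-out higher numbers stand for weaker inhibition and lower numbers for stronger inhibition), compound 2 gives 210 nM, which lies within the scatter of the only other measured compound, compound 1. Compound 3 `Cn1cc(-c2ccc(F)cc2)c2cc(C(=O)NCc3ccc(C(=O)Nc4ccccc4N)cc3)[nH]c2c1=O` keeps the shared core and has 4-fluorophenyl in place of 3-fluorophenyl on an aromatic carbon. Within the data shown here, one measured step bears on this, because it is a similar shift of the fluorine around the same phenyl ring: a 1.1-fold lower number from compound 1 to compound 2 (0.04 log units; within the scatter). That single step stays within the scatter, so no real shift is expected here either, and the estimate is no change at the digits printed from compound 2 to compound 3 (within the scatter). Compound 3 is expected at 210 nM, with an estimated range of 105 nM to 420 nM.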

Compound 3, half-maximal inhibitory concentration: 220 nM
For compound 3 the middle estimate is 1.0-fold (0.02 log units) below the measured one; the range from low to high includes it.
By their numbers in this assay, from the lowest: compounds 2, 3 and 1 (each within the scatter of the next).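

In this assay the 4-fluorophenyl group completes the set of fluorine placements on this phenyl ring, with a 1.0-fold higher number from compound 2 to compound 3 (0.02 log units; within the scatter) and a 1.0-fold lower number from compound 1 to compound 3 (0.02 log units; within the scatter). All three placements now lie within the scatter of one another, so where the fluorine sits on this ring does not separate these compounds in this assay. Nothing available here offers an explanation for this result. Still open, on these data alone, is how this ring would read with a different group in place of fluorine, such as methoxy or an amine, or with no substituent at all.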